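Adding a Second Chloro to the Purine Core

The source may hold more compounds than are shown below. What is called first, only, known or untested is meant among the compounds shown, and "the series" means these compounds.

Measured compounds:
compound 1 `CCCCCC(CCO)n1cnc2c(N)ncnc21`, > 50000 nM
compound 2 `CCCCCC(CCO)n1cnc2c(N)nc(Cl)nc21`, > 50000 nM
compound 3 `CCCCCCC(CCO)n1cnc2c(Cl)ncnc21`, 11900 nM

In a functional assay on HCT-116 cells (Homo sapiens) for antiproliferative activity, read by MTT assay, with a stated time of 48 h (on this read-out higher numbers stand for weaker inhibition and lower numbers for stronger inhibition), compound 1 gives only a limit, > 50000 nM. Compound 2 likewise reaches only a limit, > 50000 nM. The change from compound 1 to compound 2 is chloro in place of hydrogen on an aromatic carbon, and its step, a step that the two limits leave unreadable from compound 1 to compound 2, cannot be sized because of the limit of > 50000 nM in this assay, at which 2 of the 3 values shown sit. Among the measured compounds shown here, compound 3 is the one compound with a number, 11900 nM. The difference between the cores of compound 1 and compound 3 is not broken down here. Compound 4 `CCCCCCC(CCO)n1cnc2c(Cl)nc(Cl)nc21` is not yet measured; it differs from compound 3 by chloro in place of hydrogen on an aromatic carbon, the same kind of change as before, though here the place is meta to a chloro group rather than meta to an amino group. With the earlier step unreadable, compound 4 is expected near compound 3, an estimated step of a 1.5-fold lower number from compound 3 to compound 4 (0.17 log units; within the scatter), giving an expected 8000 nM (range 2500 nM to 30000 nM).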

Compound 4, half-maximal inhibitory concentration: 12100 nM
Estimate against measurement, compound 4: 1.5-fold (0.18 log units) below; low and high end bracket the measured number.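

In this assay, chloro in place of hydrogen on an aromatic carbon gives a 1.0-fold higher number from compound 3 to compound 4 (0.01 log units; within the scatter), so compound 3 and compound 4 cannot be told apart on this read-out. The same change on the core of compound 1 cannot be read, since compound 1 and compound 2 both give a limit and not a number: the limit of > 50000 nM in this assay, at which 2 of the 4 values shown sit. So the change can be read on one core only, and the compounds shown cannot say whether it behaves alike on both.

Going by these compounds, it remains open whether a methoxy group or a nitrile in place of this chloro would give a different number on the core of compound 3. On these data alone, the effect of a longer chain also remains open.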